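The source may report more compounds than this note shows. Statements on the series, on what has been measured and on what is new or still open speak of the compounds shown alone.

Measured in a functional assay on SF-295 cells (Homo sapiens) for antiproliferative activity, read by sulforhodamine B assay, with a stated time of 72 h; on this read-out lower numbers stand for stronger inhibition and higher numbers for weaker inhibition:
- compound 1 `O=S(=O)(Nc1nccs1)c1ccc(Nc2nncc3ccccc23)cc1`: 6.5 nM
- compound 2 `Fc1ccc(Nc2nncc3ccccc23)cc1`: 0.43 nM
- compound 3 `NS(=O)(=O)c1ccc(Nc2nncc3ccccc23)cc1`: 5.3 nM

Compound 3 sits close to compound 1, and both lie well above compound 2. Compound 4 `N#Cc1ccc(Nc2nncc3ccccc23)cc1` has cyano in place of sulfamoyl on an aromatic carbon.

Among the compounds with values here, two measured steps bear on this change. Changing the substituent on the sulfonamide nitrogen did little, with a 1.2-fold lower number from compound 1 to compound 3 (0.09 log units; within the scatter). Changing the group on the same aromatic carbon mattered far more, with a 12-fold higher number from compound 2 to compound 3 (1.09 log units; beyond the scatter). Within the data shown here, that second step suggests a lower number in this assay once sulfamoyl leaves, though probably a smaller shift, as no cyano compound has been measured. The expected step is a 3.5-fold lower number from compound 3 to compound 4 (0.55 log units; beyond the scatter). Compound 4 is estimated at 1.5 nM, with an expected range of 0.3 nM to 6 nM.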

Compound 4, half-maximal inhibitory concentration: 0.32 nM
Estimate against measurement, compound 4: 4.7-fold (0.67 log units) above, within the range that was stated.
By their numbers in this assay, from the lowest: compounds 4 and 2 (each within the scatter of the next); then compounds 3 and 1 (each within the scatter of the next).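

Putting cyano in place of sulfamoyl on this aromatic carbon gives a 17-fold lower number from compound 3 to compound 4 (1.22 log units; beyond the scatter) in this assay, so the higher number of compound 3 is not specific to its comparison with the fluoro compound. Cyano and fluoro cannot be told apart here, with a 1.3-fold lower number from compound 2 to compound 4 (0.13 log units; within the scatter). Nothing available explains why sulfamoyl stands apart from both.

On these data alone, it remains open whether an amine, a carboxylic acid or a methoxy group at this position would fall with cyano and fluoro or with sulfamoyl.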